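Swapping the five-membered ring at the branching carbon

A few compounds are considered here, and "the series" means these few. Any claim that something is new, unique, unknown or untested is made for them only; others in the source may bear on it.

Of the compounds shown here, three sharing one core have been measured in an assay on CHO cells for displacement of a labelled ligand from prostaglandin E2 receptor EP3 subtype (Homo sapiens), read by radioligand binding; on this read-out higher numbers stand for weaker inhibition and lower numbers for stronger inhibition. Compound 1 `CC(C)C(Cc1ncc[nH]1)c1ccc(-c2ccc3cccc(F)c3c2)[nH]c1=O` gives 11 nM. Compound 2 `CC(C)C(Nc1nccs1)c1ccc(-c2ccc3cccc(F)c3c2)[nH]c1=O` gives 9.4 nM. Compound 3 `CC(C)C(c1noc(=O)[nH]1)c1ccc(-c2ccc3cccc(F)c3c2)[nH]c1=O` gives 15 nM, the highest of the three numbers, yet its steps to the others, a 1.4-fold higher number from compound 1 to compound 3 (0.13 log units; within the scatter) and a 1.6-fold higher number from compound 2 to compound 3 (0.20 log units; within the scatter), both lie within the scatter, as does a 1.2-fold lower number from compound 1 to compound 2 (0.07 log units; within the scatter). So far, exchanging one five-membered ring for another at this position has not moved the read-out beyond noise.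

Compound 4 `CC(C)C(/C=C1/CCNC1=O)c1ccc(-c2ccc3cccc(F)c3c2)[nH]c1=O` is not yet measured. It differs from compound 3 by a group of 7 heavy atoms (5 carbon, 1 nitrogen, 1 oxygen; one five-membered non-aromatic ring with 1 hetero atom) in place of a group of 6 heavy atoms (2 carbon, 2 nitrogen, 2 oxygen; one five-membered aromatic ring with 3 hetero atoms), on a saturated chain carbon bound to an aromatic carbon and a saturated chain carbon; the entering group has one five-membered non-aromatic ring with one hetero atom and two double bonds outside aromatic rings, replacing an aromatic ring with three hetero atoms. Given that the three earlier exchanges at this carbon stayed within the scatter, the expected step of no change at the digits printed from compound 3 to compound 4 (within the scatter) is again within the scatter, with no clear direction. Compound 4 is therefore estimated at 15 nM, with a range from 5 nM to 45 nM.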

Compound 4, inhibition constant: 5.3 nM
For compound 4 the middle estimate is 2.8-fold (0.45 log units) above the measured one, and the stated range covers the measured number.
By their numbers in this assay, from the lowest: compounds 4, 2, 1 and 3 (each within the scatter of the next, the first and the last beyond it).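

In this assay, among the compounds shown here, this carbon proves sensitive to the group it carries: the entering five-membered non-aromatic ring with 1 hetero atom gives the first steps here that lie beyond the scatter, both modest (a 2.8-fold lower number from compound 3 to compound 4 (0.45 log units; beyond the scatter); a 2.1-fold lower number from compound 1 to compound 4 (0.32 log units; beyond the scatter)). The gain does not hold against every earlier group, since the step from the thiazolylamino compound stays within the scatter (a 1.8-fold lower number from compound 2 to compound 4 (0.25 log units; within the scatter)), so compound 4 cannot be ranked above compound 2. Nothing available explains this difference.

The compounds shown do not separate the effect of the non-aromatic ring from that of its double bonds outside aromatic rings. On these data alone, how a carboxylic acid or an open-chain amide on this saturated chain carbon would read also remains open.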